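Replacing 2-fluorophenyl in a series stuck at the limit

The source may hold more compounds than are shown below. What is called first, only, known or untested is meant among the compounds shown, and "the series" means these compounds.

Measured in a functional assay on MDA-MB-231 cells (Homo sapiens) for inhibition, read by sulforhodamine B assay; a lower number here means a stronger inhibitor, a higher number a weaker inhibitor:
- compound 1 (`COC(=O)CC/C(C)=C/Cc1c(OC)c(C)c2c(c1OCC#CCN1CCN(c3ccccc3F)CC1)C(=O)OC2`) gives > 50000 nM
- compound 2 (`COC(=O)CC/C(C)=C/Cc1c(OC)c(C)c2c(c1OCC#CCN1CCCc3ccccc31)C(=O)OC2`) gives > 50000 nM
- compound 3 (`COC(=O)CC/C(C)=C/Cc1c(OC)c(C)c2c(c1OCC#CCN1CCC(C(=O)OC)CC1)C(=O)OC2`) gives > 50000 nM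

Each of these entries is a limit and not a number. Compound 1 therefore stands only at a limit (> 50000 nM), with no exact value known. The same holds across the whole set (the limit of > 50000 nM in this assay, at which 3 of the 3 values shown sit).

Compound 4 (`COC(=O)CC/C(C)=C/Cc1c(OC)c(C)c2c(c1OCC#CCN1CCN(C(=O)C3COc4ccccc4O3)CC1)C(=O)OC2`) differs from compound 1 by a single change ((2,3-dihydro-1,4-benzodioxin-2-yl)carbonyl in place of 2-fluorophenyl on an amine nitrogen in a ring), with (2,3-dihydro-1,4-benzodioxin-2-yl)carbonyl in place of 2-fluorophenyl on an amine nitrogen in a ring. Among the measured compounds shown here, no measured step covers this exact swap. The only one available (a step that the two limits leave unreadable from compound 2 to compound 3) concerns other groups, and its size cannot be read. Even so, compounds 1, 2 and 3 carry different groups and all remain at the limit (the limit of > 50000 nM in this assay, at which 3 of the 3 values shown sit), so compound 4 is expected to stay there too. No step beyond the scatter is expected (a number no higher from compound 1 to compound 4 (the limit leaves the size open)). Compound 4 is estimated at 50000 nM (expected range 20000 nM to 100000 nM).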

Compound 4, half-maximal inhibitory concentration: > 50000 nM
Compound 4: only a limit was reported; the forecaster's own chance of this, stated with the estimate: 85%; the middle value sits exactly at the limit.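

No step can be read from compound 1 to compound 4, as both entries are limits and not numbers. The whole set stays at that limit: the limit of > 50000 nM in this assay, at which 4 of the 4 values shown sit.

The compounds shown leave open whether any group on the shared core gives a measurable value in this assay.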